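The source may report more compounds than this note shows. Statements on the series, on what has been measured and on what is new or still open speak of the compounds shown alone.

Two measured compounds share one core and differ only in the aryl group on the ester carbonyl. Compound 1 `COc1cc(C2Oc3cc([C@H]4Oc5cc(O)cc(O)c5C(=O)[C@@H]4O)ccc3OC2COC(=O)c2ccc(N)cc2)ccc1O` carries a 4-aminophenyl there, and in a functional assay, read by spectrophotometry, with a stated time of 30 min (a lower number here means that less compound is needed, a higher number that more compound is needed for the effect), compound 1 gives 128000 nM. Compound 2 `COc1cc(C2Oc3cc([C@H]4Oc5cc(O)cc(O)c5C(=O)[C@@H]4O)ccc3OC2COC(=O)c2cccc(Cl)c2)ccc1O` carries a 3-chlorophenyl instead, and in this assay compound 2 gives 106000 nM. The change a 1.2-fold lower number from compound 1 to compound 2 (0.08 log units; within the scatter) is within the scatter, so of the two numbers shown compound 2 stands alongside compound 1, the two indistinguishable on this evidence.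

Compound 3 `COc1cc(C2Oc3cc([C@H]4Oc5cc(O)cc(O)c5C(=O)[C@@H]4O)ccc3OC2COC(=O)c2cc(N)cc([N+](=O)[O-])c2)ccc1O` is not yet measured. It differs from compound 2 by 3-amino-5-nitrophenyl in place of 3-chlorophenyl on a carbonyl carbon. Among the measured compounds shown here, the only measured step that bears on this place is the one from compound 1 to compound 2, which exchanged one aryl group for another on the same carbonyl and moved the number within the scatter. With that single precedent, no step beyond the scatter is expected in this assay for compound 3, and the estimated step of a 1.0-fold higher number from compound 2 to compound 3 (0.02 log units; within the scatter) is expected to stay near zero. Compound 3 is therefore estimated at 110000 nM, within a range from 45000 nM to 270000 nM.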

Compound 3, half-maximal effective concentration: > 300000 nM
Compound 3: a limit, no number (the forecaster's own chance of this, stated with the estimate: 15%); middle value at least 2.7-fold (0.43 log units) from the limit.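

Compound 3 stands at a limit of the assay and not at a number: the limit of > 300000 nM in this assay, at which 1 of the 3 values shown sits. Even so, the aryl group on this carbonyl is now shown to matter: 3-amino-5-nitrophenyl in place of 3-chlorophenyl gives an at least 2.8-fold higher number from compound 2 to compound 3 (0.45 log units; beyond the scatter), and the same group in place of 4-aminophenyl gives an at least 2.3-fold higher number from compound 1 to compound 3 (0.36 log units; beyond the scatter). Among the compounds shown here, both steps lie beyond the scatter, whereas the one earlier step at this place stayed within it, so this assay does not treat every aryl group here alike, and only the lower bound of the size of these steps can be read.

As far as these compounds go, it remains open whether the nitro group or the amine of the entering group goes with this step, a question that a 3-nitrophenyl or a 3-aminophenyl on the same carbonyl would settle. Also open, from the compounds shown here alone, is whether any other group on this carbonyl, such as a pyridine ring or a short alkyl chain, would bring the number in this assay clearly lower than those of compound 1 and compound 2.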